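The source may hold more compounds than are shown below. What is called first, only, known or untested is meant among the compounds shown, and "the series" means these compounds.

Compound 1 `COc1cc(C(=O)c2sc3ccccc3c2-c2ccccc2)cc(OC)c1OC`: 1900 nM
Compound 2 `COc1cc(C(=O)c2sc3ccccc3c2-c2ccc(F)cc2)cc(OC)c1OC`: 3000 nM

In a functional assay on HeLa cells (Homo sapiens) for antiproliferative activity, read by MTT assay, with a stated time of 72 h (a higher number here means a weaker inhibitor, a lower number a stronger inhibitor), only these two compounds have been measured so far. For the measured compounds named here, compound 1 stands level with compound 2, its sole neighbour on the scale: a 1.6-fold higher number from compound 1 to compound 2 (0.20 log units; within the scatter).

Compound 3 `COc1cc(C(=O)c2sc3ccccc3c2-c2ccc(Cl)cc2)cc(OC)c1OC` has not yet been measured. Its difference from compound 1 is chloro in place of hydrogen on an aromatic carbon In words, this is chloro in place of hydrogen on an aromatic carbon, turning phenyl into 4-chlorophenyl.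

One measured step bears on this change, fluoro in place of hydrogen on an aromatic carbon, and it is the step from compound 1 to compound 2 given above. That single step stayed within the scatter, and it involved a different atom, so the evidence is thin. No shift beyond the scatter is expected, in either direction. The expected change is a 1.3-fold higher number from compound 1 to compound 3 (0.12 log units; within the scatter). In this assay, the estimated value for compound 3 is 2500 nM, with an expected range from 1000 nM to 6000 nM.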

Compound 3, half-maximal inhibitory concentration: 5200 nM
For compound 3 the middle estimate is 2.1-fold (0.32 log units) below the measured one; low and high end bracket the measured number.
By their numbers in this assay, from the lowest: compounds 1, 2 and 3 (each within the scatter of the next, the first and the last beyond it).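

In this assay, for the compounds shown here, chloro in place of hydrogen on this aromatic carbon, para to a large group, gives the first step at this position that lies beyond the scatter (a 2.7-fold higher number from compound 1 to compound 3 (0.44 log units; beyond the scatter)). The position therefore responds to at least one replacement of its hydrogen, though the step is modest, while the two halogens cannot be told apart from each other (a 1.7-fold higher number from compound 2 to compound 3 (0.24 log units; within the scatter)). No measurement on hand gives a reason for the size of the chloro step.

With only fluoro and chloro shown at this place, it remains open whether a larger halogen such as bromo, or a quite different group such as an amine or a carboxylic acid, would move the number the same way. Also open, as far as these compounds go, is whether chloro would give a similar step on another carbon of this ring.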